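A few compounds are considered here, and "the series" means these few. Any claim that something is new, unique, unknown or untested is made for them only; others in the source may bear on it.

Measured so far:
- compound 1, `Cc1nn(-c2nc(-c3ccc(Cl)c(Cl)c3)c(SC(C)C)s2)c(C(=O)O)c1-c1cccc(C(F)(F)F)c1`: 22000 nM
- compound 2, `Cc1cccc(-c2c(C)nn(-c3nc(-c4ccc(Cl)c(Cl)c4)c(SC(C)C)s3)c2C(=O)O)c1`: 17000 nM
- compound 3, `COc1ccc(C)cc1-c1c(C)nn(-c2nc(-c3ccc(Cl)c(Cl)c3)c(SC(C)C)s2)c1C(=O)O`: 9500 nM

These three compounds share one core and differ only in the aryl group attached to it. In a functional assay on BJAB cells (Homo sapiens) for antiproliferative activity, with a stated time of 4 days (on this read-out higher numbers stand for an effect only at larger amounts of compound and lower numbers for an effect already at smaller amounts), compound 3 gives the lowest number of the three; its gap to compound 2 lies within the scatter, while its gap to compound 1 is beyond it, as a 2.3-fold lower number from compound 1 to compound 3 (0.36 log units; beyond the scatter) shows. The aryl swaps so far moved this assay only a little: a 1.3-fold lower number from compound 1 to compound 2 (0.11 log units; within the scatter) and a 1.8-fold lower number from compound 2 to compound 3 (0.25 log units; within the scatter) are both within the scatter.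

Compound 4, `CCOc1ncccc1-c1c(C)nn(-c2nc(-c3ccc(Cl)c(Cl)c3)c(SC(C)C)s2)c1C(=O)O`, differs from compound 3 by 2-ethoxypyridin-3-yl in place of 2-methoxy-5-methylphenyl on an aromatic carbon. Among the measured compounds shown here, no measured step covers this exact swap, so the estimate rests on the general observation that aryl changes on this core have shifted the read-out only modestly. A change of no more than a small size, in either direction, is therefore expected, a 1.3-fold higher number from compound 3 to compound 4 (0.10 log units; within the scatter). For compound 4 in this assay the expected value is 12000 nM, with a likely range from 5000 nM to 30000 nM.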

Compound 4, half-maximal effective concentration: 11000 nM
Estimate against measurement, compound 4: 1.1-fold (0.04 log units) above, within the range that was stated.
By their numbers in this assay, from the lowest: compounds 3, 4, 2 and 1 (each within the scatter of the next, the first and the last beyond it).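

In this assay, among the compounds shown here, this position accepts 2-ethoxypyridin-3-yl, the only group so far with a hetero atom in its ring, in place of 2-methoxy-5-methylphenyl (a 1.2-fold higher number from compound 3 to compound 4 (0.06 log units; within the scatter)), 3-methylphenyl (a 1.5-fold lower number from compound 2 to compound 4 (0.19 log units; within the scatter)) and 3-(trifluoromethyl)phenyl (a 2.0-fold lower number from compound 1 to compound 4 (0.30 log units; within the scatter)). All three steps lie within the scatter, so among these compounds a ring of carbon only is not required for a number of this size. Nothing at hand explains why the numbers stay so close.

As far as these compounds go, this swap changes the ring atom, the ether chain and the ring methyl at once, so the share of each stays open; 2-methoxypyridin-3-yl would separate the first two. Also open, from the compounds shown here alone, is how this position responds to an amine on the ring or a longer chain such as butoxy.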